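The compounds below may be only part of what the source reports. "The series", "measured", "known", "first", "only" and "open" are said of these compounds alone.

Compound 1 `COc1ccccc1CNc1ncnc2c1ncn2C1CCCCO1` is the starting point: in an ADME assay on K562 cells (Homo sapiens) for cytotoxicity, with a stated time of 72 h (a higher number here means a weaker inhibitor, a lower number a stronger inhibitor), compound 1 gives 97000 nM. Compound 2 `COc1cccc(OC)c1CNc1ncnc2c1ncn2C1CCCCO1` carries one more group, described as methoxy in place of hydrogen on an aromatic carbon, and in this assay compound 2 gives 10300 nM, a step of a 9.4-fold lower number from compound 1 to compound 2 (0.97 log units; beyond the scatter). Compound 3 `COc1ccc(CNc2ncnc3c2ncn3C2CCCO2)c(OC)c1` has a different core; how it differs from the core of compound 1 is not broken down here. In this assay compound 3 gives only a limit, > 100000 nM, and this is the limit (the limit of > 100000 nM in this assay, at which 1 of the 3 values shown sits). Compound 4 `COc1ccc(CNc2ncnc3c2ncn3C2CCCO2)c(OC)c1OC` is not yet measured; it differs from compound 3 by methoxy in place of hydrogen on an aromatic carbon, the same kind of change as before, but here the entering group sits ortho to two methoxy groups and meta to a large group, whereas in compound 2 it sits ortho to a large group and meta to a methoxy group. Since compound 3 gives only a limit, the size of the step is uncertain; by analogy with a 9.4-fold lower number from compound 1 to compound 2 (0.97 log units; beyond the scatter) a step of about an at least 2.5-fold lower number from compound 3 to compound 4 (0.39 log units; beyond the scatter) is expected. Compound 4 is therefore estimated at 40000 nM, within 8000 nM to 150000 nM.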

Compound 4, half-maximal inhibitory concentration: > 100000 nM
Compound 4: a limit, no number (the forecaster's own chance of this, stated with the estimate: 40%); middle value at least 2.5-fold (0.39 log units) from the limit.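

In this assay, going by these compounds alone, compound 3 and compound 4 both give only a limit, so no step between them can be read: the limit of > 100000 nM in this assay, at which 2 of the 4 values shown sit. The compounds shown leave open whether methoxy in place of hydrogen changes the number at all on the core of compound 3.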